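Urea Substituent Changes in Rabbit Microsomal ACAT Inhibition

The compounds below may be only part of what the source reports. "The series", "measured", "known", "first", "only" and "open" are said of these compounds alone.

Compound 1 `CCCCNC(=O)Nc1c(OCCCn2cnc(-c3ccccc3)c2)cccc1N(C)C` and compound 2 `CN(C)c1cccc(OCCCn2cnc(-c3ccccc3)c2)c1NC(=O)NC1CCCC1` share the same core and differ only at the urea end. In an assay for inhibition of acyl-CoA:cholesterol acyltransferase (Oryctolagus cuniculus), using microsomes (a lower number here means a stronger inhibitor, a higher number a weaker inhibitor), compound 1 gives 140 nM, and compound 2 gives 240 nM; the step of a 1.7-fold higher number from compound 1 to compound 2 (0.23 log units; within the scatter) is small. For the measured compounds named here, compound 2 thus holds the higher of the two numbers known so far, though its gap to compound 1 lies within the scatter.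

Compound 3 `CCCCCN(C)C(=O)Nc1c(OCCCn2cnc(-c3ccccc3)c2)cccc1N(C)C` carries a further change at the same position: methyl(pentyl)amino in place of cyclopentylamino on a carbonyl carbon. Going by the values given here, the only measured step that bears on it, a 1.7-fold higher number from compound 1 to compound 2 (0.23 log units; within the scatter), swapped one chain for another while keeping the amide hydrogen; here that hydrogen is replaced and the chain is lengthened, so the known step offers limited guidance. For compound 3 a somewhat higher number is expected, with wide uncertainty, giving an estimate of 500 nM (range 120 nM to 2500 nM), a step of a 2.1-fold higher number from compound 2 to compound 3 (0.32 log units; beyond the scatter).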

Compound 3, half-maximal inhibitory concentration: 550 nM
Compound 3: middle estimate off by 1.1-fold (0.04 log units), on the low side; low and high end bracket the measured number.
By their numbers in this assay, from the lowest: compounds 1 and 2 (each within the scatter of the next); then compound 3.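

The urea end does respond to change: in this assay, moving to methyl(pentyl)amino on the carbonyl carbon gives a 2.3-fold higher number from compound 2 to compound 3 (0.36 log units; beyond the scatter) and also a 3.9-fold higher number from compound 1 to compound 3 (0.59 log units; beyond the scatter) in the comparison with the butylamino compound. Both steps are beyond the scatter, so compound 3 is the weakest inhibitor of the three, whereas the swap between the two groups that keep the amide hydrogen stayed within the scatter. No supporting data are available to explain this rise.

As far as these compounds go, compound 3 differs in two ways at once, since it loses the amide hydrogen and also carries a different chain, so the share of each in the rise stays open. Pentylamino, which keeps that hydrogen, and methyl(butyl)amino, which lacks it but keeps the butyl chain, would help separate the two.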